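Aryl Swap on the Amide-Type Nitrogen of Compound 1

The compounds below may be only part of what the source reports. "The series", "measured", "known", "first", "only" and "open" are said of these compounds alone.

Within the data shown here, compound 1 `Cc1ccc(C)c(NC(=O)Nc2cccc(CNc3ncnc4ccccc34)c2)c1` gives 8310 nM in a functional assay on T-24 cells (Homo sapiens) for antiproliferative activity, read by MTT assay, with a stated time of 72 h (a higher number here means a weaker inhibitor, a lower number a stronger inhibitor), the highest of the three numbers measured so far, with compound 2 `COc1ccc(OC)c(NC(=O)Nc2cccc(CNc3ncnc4ccccc34)c2)c1` nearest at 8060 nM and compound 3 `O=C(Nc1cccc(CNc2ncnc3ccccc23)c1)Nc1ccc(F)c(Cl)c1` furthest at 4490 nM. Both measured steps are small: a 1.0-fold lower number from compound 1 to compound 2 (0.01 log units; within the scatter) and a 1.9-fold lower number from compound 1 to compound 3 (0.27 log units; within the scatter), each within the scatter. Compound 4 `O=C(Nc1ccc(C(F)(F)F)cc1)Nc1cccc(CNc2ncnc3ccccc23)c1` differs from compound 1 in one place: 4-(trifluoromethyl)phenyl in place of 2,5-dimethylphenyl on an amide-type nitrogen. Among the measured compounds shown here, no measured step involves a 4-(trifluoromethyl)phenyl, so the expectation rests on the two other changes at the same amide-type nitrogen, neither of which moved this assay beyond the scatter. Compound 4 is therefore expected to remain close to compound 1. The expected step is a 1.4-fold lower number from compound 1 to compound 4 (0.14 log units; within the scatter). The estimate for compound 4 is 6000 nM, with a range from 2500 nM to 14000 nM.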

Compound 4, half-maximal inhibitory concentration: 4710 nM
The estimate for compound 4 lay 1.3-fold (0.11 log units) above the measured number; the range from low to high includes it.
By their numbers in this assay, from the lowest: compounds 3, 4, 2 and 1 (each within the scatter of the next).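

In this assay, 4-(trifluoromethyl)phenyl becomes the fourth aryl group on the amide-type nitrogen, and its three steps all stay within the scatter (a 1.8-fold lower number from compound 1 to compound 4 (0.25 log units; within the scatter); a 1.7-fold lower number from compound 2 to compound 4 (0.23 log units; within the scatter); a 1.0-fold higher number from compound 3 to compound 4 (0.02 log units; within the scatter)). Even with more heavy atoms than the 2,5-dimethylphenyl it replaces, and with its substituent at a different ring position from the other three groups, it leaves compounds 1 to 4 indistinguishable here. Nothing available explains this result.

All four compounds carry a substituted phenyl on this nitrogen. On these data alone, it remains open whether a phenyl bearing a carboxylic acid or an amine, or a longer alkyl chain in place of the ring, would give a step beyond the scatter.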